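A few compounds are considered here, and "the series" means these few. Any claim that something is new, unique, unknown or untested is made for them only; others in the source may bear on it.

Compound 3 `COc1ccc(CN(C(=O)CSc2nc3ccccc3s2)c2cc(OC)c(OC)c(OC)c2)cc1OC` gives 34100 nM in a functional assay on MGC-803 cells (Homo sapiens) for antiproliferative activity, read by MTT assay, with a stated time of 48 h (a higher number here means a weaker inhibitor, a lower number a stronger inhibitor), and stands second highest of the three numbers measured: its nearest neighbour is compound 1 `COc1cc(N(Cc2ccccc2)C(=O)CSc2nc3ccccc3s2)cc(OC)c1OC` at 44300 nM, while compound 2 `COc1ccc(CN(C(=O)CSc2nc3ccccc3s2)c2cc(OC)c(OC)c(OC)c2)cc1` lies far lower at 163 nM. Compound 4 `COc1ccc(CN(C(=O)CSc2nc3ccccc3s2)c2cc(OC)c(OC)c(OC)c2)cc1Br` differs from compound 3 by bromo in place of methoxy on an aromatic carbon. For the measured compounds named here, no measured step makes this exact change. The steps touching the same aromatic carbon are a 270-fold lower number from compound 1 to compound 2 (2.43 log units; beyond the scatter) and a 210-fold higher number from compound 2 to compound 3 (2.32 log units; beyond the scatter), whereas a 1.3-fold lower number from compound 1 to compound 3 (0.11 log units; within the scatter) changed little. Because a 210-fold higher number from compound 2 to compound 3 (2.32 log units; beyond the scatter) was large and upward, bromo in place of methoxy is expected to recover part of that loss, giving an expected step of an 11-fold lower number from compound 3 to compound 4 (1.06 log units; beyond the scatter). Compound 4 is therefore estimated at 3000 nM, with a range from 300 nM to 30000 nM.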

Compound 4, half-maximal inhibitory concentration: 852 nM
Compound 4: the middle estimate sits 3.5-fold (0.55 log units) above what was measured; the range from low to high includes it.
By their numbers in this assay, from the lowest: compound 2; then compound 4; then compounds 3 and 1 (each within the scatter of the next).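

On the 3,4-dimethoxybenzyl group, the methoxy at this position proves replaceable, as bromo in its place restores much of the lost activity (a 40-fold lower number from compound 3 to compound 4 (1.60 log units; beyond the scatter)). Bromo still falls short of hydrogen there (a 5.2-fold higher number from compound 2 to compound 4 (0.72 log units; beyond the scatter)), yet the 3-bromo-4-methoxyphenyl group clearly improves on plain phenyl (a 52-fold lower number from compound 1 to compound 4 (1.72 log units; beyond the scatter)), so the outcome depends strongly on which group occupies this carbon. No available evidence accounts for these differences. On these data alone, whether chloro or an amine at this position would behave like bromo stays open, as does whether any group there could match or pass hydrogen.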